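A few compounds are considered here, and "the series" means these few. Any claim that something is new, unique, unknown or untested is made for them only; others in the source may bear on it.

Measured compounds:
- Compound 1, `O=S(=O)(Nc1ccc2oc(-c3ccccc3)nc2c1)c1ccc(O)cc1`: 88000 nM
- Compound 2, `O=S(=O)(Nc1ccc(-c2nc3ccccc3o2)cc1)c1ccc(O)cc1`: 78000 nM

The two compounds were tested in an assay on cells for inhibition of HSP60/HSP10 (Homo sapiens), with a stated time of 60 min; a higher number here means a weaker inhibitor, a lower number a stronger inhibitor. There compound 1 gives 88000 nM and compound 2 gives 78000 nM. The two numbers lie within the usual scatter of each other, so the two compounds cannot be told apart on these data; compound 2 carries the lower of the two figures, but that difference means nothing here.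

Compound 3, `O=S(=O)(Nc1ccc(-c2nc3cc(NS(=O)(=O)c4ccc(O)cc4)ccc3o2)cc1)c1ccc(O)cc1`, has not yet been measured in this assay. Compared with compound 2, the change is ((4-hydroxyphenyl)sulfonyl)amino in place of hydrogen on an aromatic carbon. For the measured compounds named here, no step between measured compounds is known, so the expected direction rests only on the size of the change and the weak values seen so far. A modest step to a lower number is expected, a 1.6-fold lower number from compound 2 to compound 3 (0.19 log units; within the scatter). For compound 3 the estimate in this assay is 50000 nM, within a range from 15000 nM to 150000 nM.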

Compound 3, half-maximal inhibitory concentration: 14000 nM
For compound 3 the middle estimate is 3.6-fold (0.55 log units) above the measured one; the measured number lies below the stated range.
By their numbers in this assay, from the lowest: compound 3; then compounds 2 and 1 (each within the scatter of the next).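

Replacing hydrogen with ((4-hydroxyphenyl)sulfonyl)amino on an aromatic carbon of the fused system of two rings gives a 5.6-fold lower number from compound 2 to compound 3 (0.75 log units; beyond the scatter) in this assay, so this position accepts a large added group and the number falls clearly. Compounds 1 and 2 each carry one such group and could not be told apart, whereas compound 3 carries two and separates from both, with a 6.3-fold lower number from compound 1 to compound 3 (0.80 log units; beyond the scatter) as the matching step from the other single-group compound. No measurement shown here explains this gain.

Going by these compounds, it remains open whether the whole added group is needed, or whether a simple amine at the same position would give a similar step. On these data alone, it is equally open whether the hydroxyl on the added ring matters, as a methoxy group or a carboxylic acid in its place would show.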